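Ring substituent swap: nitro out, chlorine in

This account rests on a few compounds, and the source may have more. Where it says the series, first, only, none or still open, it means among the compounds named here.

Compound 1, `CC1=CC[C@@H]([C@@](C)(O)CCCC(C)(C)NC(=S)N/N=C\c2ccc(N(C)C)cc2)CC1`: in a functional assay on HT-29 cells (Homo sapiens) for cytotoxicity, read by sulforhodamine B assay (a lower number here means that less compound is tolerated, a higher number that more compound is tolerated), compound 1 gives > 100000 nM, a limit of the assay.
Compound 2, `CC1=CC[C@@H]([C@@](C)(O)CCCC(C)(C)NC(=S)N/N=C\c2ccccc2[N+](=O)[O-])CC1`: in this assay compound 2 gives 44400 nM.
Compound 3, `CC1=CC[C@@H]([C@@](C)(O)CCCC(C)(C)NC(=S)N/N=C\c2ccc([N+](=O)[O-])cc2)CC1`: in this assay compound 3 gives > 100000 nM, again a limit.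

Compound 3 therefore stands at the limit of > 100000 nM in this assay, at which 2 of the 3 values shown sit, with no exact number. Compound 4, `CC1=CC[C@@H]([C@@](C)(O)CCCC(C)(C)NC(=S)N/N=C\c2ccccc2Cl)CC1`, differs from it by 2-chlorophenyl in place of 4-nitrophenyl on a carbon with a double bond to nitrogen. The step that bears on this is an at least 2.2-fold higher number from compound 2 to compound 3 (0.35 log units; beyond the scatter), which shows a ring substituted at the same 2-position giving a lower number than the 4-nitrophenyl ring; a step that the two limits leave unreadable from compound 1 to compound 3 gives no readable size. A modest fall in this assay is therefore expected, roughly an at least 2.0-fold lower number from compound 3 to compound 4 (0.30 log units; that floor lies within the scatter). Compound 4 is estimated at 50000 nM, expected between 20000 nM and 120000 nM.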

Compound 4, concentration lethal to 50% of the cells: > 100000 nM
Compound 4: a limit, no number (the forecaster's own chance of this, stated with the estimate: 35%); at least 2.0-fold (0.30 log units) between middle value and limit.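

Chloro in place of nitro on an aromatic carbon gives an at least 2.2-fold higher number from compound 2 to compound 4 (0.35 log units; beyond the scatter), so among the compounds shown, the lower number goes with the 2-nitrophenyl of compound 2 and not with the 2-chlorophenyl of compound 4. The steps from compound 3 and from compound 1 to compound 4 cannot be read, since both ends of each are limits. Most of the set now sits at one limit: the limit of > 100000 nM in this assay, at which 3 of the 4 values shown sit.

Still open, from the compounds shown here alone, is whether an amine or a methoxy group in place of that nitro would give a number like that of compound 2. Going by these compounds, how the sizes of compound 1, compound 3 and compound 4 compare also stays unknown.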